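Acetate to hemisuccinate-type ester on the shared core

A few compounds are considered here, and "the series" means these few. Any claim that something is new, unique, unknown or untested is made for them only; others in the source may bear on it.

In a functional assay on MCF7 cells (Homo sapiens) for antiproliferative activity, read by MTT assay, with a stated time of 72 h (on this read-out lower numbers stand for stronger inhibition and higher numbers for weaker inhibition), compound 1 `CC1=CC[C@H]2[C@@H]1CC=C(C)[C@@H](CC[C@H]1[C@]3(C)CC[C@H](O)C(C)(C)O[C@H]3CC[C@@]1(C)O)C2(C)C` gives > 50000 nM, which is a limit of the assay. Compound 3 `CC(=O)O[C@H]1CC[C@]2(C)[C@H](CC[C@@](C)(O)[C@H]2CC[C@@H]2C(C)=CC[C@@H]3C(C)=CC[C@@H]3C2(C)C)OC1(C)C` gives 43500 nM. Among the compounds with values here, its only measured neighbour by number is compound 2 `CC1=CC[C@H]2[C@H](CC[C@]2(C)O)C(C)(C)[C@@H]1CC[C@H]1[C@]2(C)CC[C@H](OC(=O)c3ccncc3)C(C)(C)O[C@H]2CC[C@@]1(C)O` at 25300 nM, and these two values lie within the scatter of each other.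

Compound 4 `CC1=CC[C@H]2[C@@H]1CC=C(C)[C@@H](CC[C@H]1[C@]3(C)CC[C@H](OC(=O)CCC(=O)O)C(C)(C)O[C@H]3CC[C@@]1(C)O)C2(C)C` keeps the core of compound 3 and extends its ester, with acetyl going to (2-carboxyethyl)carbonyl. The change is carboxymethyl in place of hydrogen on a saturated chain carbon bound to a carbonyl carbon.

Within the data shown here, one measured step bears on this oxygen substituent. It is acetyl in place of hydrogen, an at least 1.1-fold lower number from compound 1 to compound 3 (0.06 log units; that floor lies within the scatter). Among the measured compounds shown here, no measured compound carries the carboxymethyl, so this step is only a loose guide. In this assay no shift beyond the scatter is therefore expected, and the estimated step is a 1.2-fold lower number from compound 3 to compound 4 (0.09 log units; within the scatter). For compound 4 the estimate is 35000 nM, with an expected range from 15000 nM to 70000 nM.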

Compound 4, half-maximal inhibitory concentration: > 50000 nM
Compound 4 ended at the assay's limit; the forecaster's own chance of this, stated with the estimate: 30%; at least 1.4-fold (0.15 log units) between middle value and limit.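

In this assay compound 4 gives > 50000 nM, which is a limit of the assay. Extending the acetyl on this oxygen to (2-carboxyethyl)carbonyl gives an at least 1.1-fold higher number from compound 3 to compound 4 (0.06 log units; that floor lies within the scatter), so the carboxymethyl shows no gain in potency here, while the true size of the step stays unknown and its floor does not pass the scatter. The step from compound 1 to compound 4 cannot be read, and the readable range at this oxygen ends at one limit: the limit of > 50000 nM in this assay, at which 2 of the 4 values shown sit.

Still open, on these data alone, is whether the missing gain belongs to the terminal carboxylic acid or to the chain that carries it. An ester of the same length ending in a methyl ester or an amine, or a longer chain at this oxygen, would separate these two readings.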